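The source may hold more compounds than are shown below. What is called first, only, known or untested is meant among the compounds shown, and "the series" means these compounds.

Working notes on the series. Compound 1 `Cc1cccc(CNc2cc(C)nc3c(-c4ccccc4)c(C)nn23)n1` opens the set. In a physicochemical assay for solubility, read by HPLC, using the shake flask method, measured as kinetic solubility, with a stated time of 2 h, at pH 7.4 (on this read-out lower numbers stand for lower solubility and higher numbers for higher solubility), compound 1 gives < 5000 nM, which is a limit of the assay rather than a number. The value of compound 1 is the one that sits at the limit (the limit of < 5000 nM in this assay, at which 1 of the 3 values shown sits). Compound 2 `Cc1cc(NCc2ccccn2)n2ncc(-c3cccc(F)c3)c2n1` gives 5000 nM in this assay. Compound 3 `Cc1cc(NCc2ccccn2)n2ncc(-c3ccc(C(=O)Nc4ccccc4)cc3)c2n1` gives 5000 nM in this assay, level with compound 2 at the digits recorded and within the usual scatter, so no order between compound 2 and compound 3 can be read. Among the measured compounds shown here, no two of the measured compounds differ in only one place, so no measured step is available on which to rest.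

Compound 4 `Cc1cc(NCc2ccccn2)n2ncc(C3=CCC(F)(F)CC3)c2n1` is the next compound for this assay. It differs from compound 2 as follows: 4,4-difluorocyclohex-1-en-1-yl in place of 3-fluorophenyl on an aromatic carbon. For the measured compounds named here, with no measured step for guidance, the expected step from compound 2 to compound 4 is a 1.4-fold higher number from compound 2 to compound 4 (0.15 log units; within the scatter), a small shift upward if any, not clearly beyond the scatter. Compound 4 is therefore expected to give 7000 nM in this assay, with a range from 3000 nM to 20000 nM, and a real chance that only a limit is reported.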

Compound 4, solubility: 5000 nM
The estimate for compound 4 lay 1.4-fold (0.15 log units) above the measured number; the range from low to high includes it.
By their numbers in this assay, from the lowest: compounds 2, 3 and 4 (each within the scatter of the next).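

In this assay, 4,4-difluorocyclohex-1-en-1-yl in place of 3-fluorophenyl on an aromatic carbon of the five-membered aromatic ring gives no change at the digits printed from compound 2 to compound 4 (within the scatter). Among the compounds shown here, this is the first measured step at this position: a six-membered non-aromatic ring of carbon only takes the place of a six-membered aromatic ring of carbon only, and the read-out does not separate the two. Compound 1 still stands as a limit of the assay rather than a number: the limit of < 5000 nM in this assay, at which 1 of the 4 values shown sits.

Going by these compounds, what an amine or a carboxylic acid at this position would give remains open. Also open, on these data alone, is whether any change here can move the read-out in this assay beyond the scatter.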